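Working notes on compounds 1 to 4

The source may report more compounds than this note shows. Statements on the series, on what has been measured and on what is new or still open speak of the compounds shown alone.

Measured so far:
compound 1 `CC(C)n1nc(N2CC(CO)C2)c2cnc(Nc3ccnc(-c4cnn(S(=O)(=O)C5CC5)c4)n3)cc21`: 13 mL/min/kg
compound 2 `CC(C)n1nc(N2CC(C(C)(C)O)C2)c2cnc(Nc3ccnc(-c4cnn(S(=O)(=O)C5CC5)c4)n3)cc21`: 7.1 mL/min/kg
compound 3 `CC(C)c1nn(C(C)C)c2cc(Nc3ccnc(-c4cnn(S(=O)(=O)C5CC5)c4)n3)ncc12`: 15 mL/min/kg

In an ADME assay on cells (Hepatocyte, Homo sapiens) for pharmacokinetics (on this read-out lower numbers stand for slow clearance and higher numbers for fast clearance), the number for compound 2 is the lowest of the three, though compound 1 sits within the scatter of it (a 1.8-fold lower number from compound 1 to compound 2 (0.26 log units; within the scatter)), while the step to compound 3 goes beyond it (a 2.1-fold higher number from compound 2 to compound 3 (0.32 log units; beyond the scatter)). Compound 4 `CC[C@H](C)n1nc(N2CC(C(C)(C)O)C2)c2cnc(Nc3ccnc(-c4cnn(S(=O)(=O)C5CC5)c4)n3)cc21` is not yet measured; it differs from compound 2 by methyl in place of hydrogen on a saturated chain carbon, two bonds along the chain from an aromatic nitrogen. Among the compounds with values here, no measured step touches this position: the steps through compound 1 (a 1.2-fold higher number from compound 1 to compound 3 (0.06 log units; within the scatter)) concern the group on the aromatic carbon instead. With nothing bearing on it directly, no step beyond the scatter is expected. The number for compound 4 is estimated at 8.5 mL/min/kg, range 4.5 mL/min/kg to 16 mL/min/kg, an expected step of a 1.2-fold higher number from compound 2 to compound 4 (0.08 log units; within the scatter).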

Compound 4, clearance: 2.7 mL/min/kg
Estimate against measurement, compound 4: 3.1-fold (0.50 log units) above; the whole stated range lies above it.
By their numbers in this assay, from the lowest: compound 4; then compounds 2, 1 and 3 (each within the scatter of the next, the first and the last beyond it).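

The position on the saturated chain carbon, two bonds along the chain from an aromatic nitrogen, responds in this assay: isopropyl to sec-butyl gives (a 2.6-fold lower number from compound 2 to compound 4 (0.42 log units; beyond the scatter)), a modest step. Within the data shown here, the earlier steps concerned only the group on the aromatic carbon, so this is the first reading at this place. Nothing at hand explains the step.

Open, from the compounds shown here alone, is whether a longer chain or a cyclopropyl group here, or the opposite configuration of sec-butyl, gives a similar number. Also open, going by these compounds, is whether the step carries over to the hydroxymethyl azetidine of compound 1.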